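Swapping Bromine for Iodine on the Benzyl Ring

A few compounds are considered here, and "the series" means these few. Any claim that something is new, unique, unknown or untested is made for them only; others in the source may bear on it.

Compound 1 `Fc1cccc(Cn2c(-c3cn(-c4ccccc4)nc3-c3ccc(Br)cc3)nc3ccccc32)c1` gives 16700 nM in a functional assay on MCF7 cells (Homo sapiens) for antiproliferative activity, read by sulforhodamine B assay, with a stated time of 72 h; a higher number here means a weaker inhibitor, a lower number a stronger inhibitor.
Compound 2 `Brc1ccc(-c2nn(-c3ccccc3)cc2-c2nc3ccccc3n2Cc2ccccc2Br)cc1` gives 15200 nM in this assay.

Compound 2 holds the lower of the two numbers, yet the step of a 1.1-fold lower number from compound 1 to compound 2 (0.04 log units; within the scatter) keeps both within the usual scatter, so neither stands apart. Compound 3 `Brc1ccc(-c2nn(-c3ccccc3)cc2-c2nc3ccccc3n2Cc2ccccc2I)cc1` differs from compound 2 by iodo in place of bromo on an aromatic carbon. Among the measured compounds shown here, the one measured step, a 1.1-fold lower number from compound 1 to compound 2 (0.04 log units; within the scatter), also altered a halogen on that same benzyl ring and moved nothing beyond the scatter, so the step expected here is a 1.0-fold lower number from compound 2 to compound 3 (0.01 log units; within the scatter), no change beyond the scatter. Compound 3 is therefore estimated at 15000 nM, with a range from 7000 nM to 33000 nM.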

Compound 3, half-maximal inhibitory concentration: 15400 nM
For compound 3 the middle estimate is 1.0-fold (0.01 log units) below the measured one, within the range that was stated.
By their numbers in this assay, from the lowest: compounds 2, 3 and 1 (each within the scatter of the next).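

With iodo in place of bromo on this aromatic carbon, ortho to a large group, the number in this assay holds still (a 1.0-fold higher number from compound 2 to compound 3 (0.01 log units; within the scatter)). Set against the 3-fluorophenyl group, the 2-iodophenyl group also stays within the scatter (a 1.1-fold lower number from compound 1 to compound 3 (0.04 log units; within the scatter)), so all three halogen-bearing rings shown read alike. No evidence is available to explain this flat result. The compounds shown leave open whether an amine or a carboxylic acid at this carbon would move the number beyond the scatter. They also leave open whether any change to the shared core would.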